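This account rests on a few compounds, and the source may have more. Where it says the series, first, only, none or still open, it means among the compounds named here.

Going by the values given here, in a functional assay on OVCAR-8 cells (Homo sapiens) (on this read-out lower numbers stand for stronger inhibition of growth and higher numbers for weaker inhibition of growth), compound 1 (`O=S(=O)(/C=C/c1ccc(F)cc1)Cc1ccc(Nc2ncnc3ccccc23)cc1`) gives 2000 nM, while compound 2 (`O=S(=O)(/C=C/c1ccc(C(F)(F)F)cc1F)Cc1ccc(Nc2ncnc3ccccc23)cc1`) gives 100000 nM, the higher of the two numbers measured so far. Compound 3 (`O=S(=O)(/C=C/c1ccc(O)cc1)Cc1ccc(Nc2ncnc3ccccc23)cc1`) keeps the shared core and alters only the aromatic group on the double-bonded chain carbon: 4-hydroxyphenyl in place of 2-fluoro-4-(trifluoromethyl)phenyl on a double-bonded chain carbon bound to a double-bonded chain carbon. Just one measured step bears on this change, a 50-fold higher number from compound 1 to compound 2 (1.70 log units; beyond the scatter). That large step, beyond the scatter, arose at the same place. Among the compounds with values here, the data hold no measured example of a 4-hydroxyphenyl group, so any expectation rests on this single pair. By name, the entering group resembles the 4-fluorophenyl of compound 1, which gives 2000 nM, more than the group it replaces, so a large move towards a lower number is expected. The estimated change is a 40-fold lower number from compound 2 to compound 3 (1.60 log units; beyond the scatter). For compound 3 the expected value is 2500 nM, within an estimated range of 600 nM to 12000 nM.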

Compound 3, concentration for 50% growth inhibition: 1000 nM
For compound 3 the middle estimate is 2.5-fold (0.40 log units) above the measured one; the range from low to high includes it.
By their numbers in this assay, from the lowest: compounds 3 and 1 (each within the scatter of the next); then compound 2.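

In this assay the step of a 100-fold lower number from compound 2 to compound 3 (2.00 log units; beyond the scatter) shows that the weak result of compound 2 does not hold for every substituted phenyl group at this place, on a double-bonded chain carbon bound to a double-bonded chain carbon. Hydroxy in place of fluoro on an aromatic carbon gives a 2.0-fold lower number from compound 1 to compound 3 (0.30 log units; within the scatter) and so cannot be told apart on this read-out. No evidence is available to explain why the 2-fluoro-4-(trifluoromethyl)phenyl group stands apart from the other two groups.

Compound 2 carries both a fluoro and a trifluoromethyl group, so a phenyl ring bearing the trifluoromethyl group alone would be needed to show which of them goes with the weaker growth inhibition. From the compounds shown here alone, whether an amine or a carboxylic acid on the ring would match compounds 1 and 3 also remains open.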